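Amide substituent changes on a shared core in rat paw edema

The source may report more compounds than this note shows. Statements on the series, on what has been measured and on what is new or still open speak of the compounds shown alone.

Compound 2 `CN(C)CCNC(=O)c1c(O)c2cccnc2n(-c2ccccc2)c1=O` sits second highest of the three numbers measured in a functional assay on the whole organism for inhibition, with Rattus norvegicus as the target, read by cytopathic effect and paw edema, at a dose of 100 mg/kg by the oral route (on this read-out lower numbers stand for less inhibition and higher numbers for more inhibition at the one dose given (going by the name of the read-out)), where compound 2 gives 18.4%. Compound 1 `CCCCNC(=O)c1c(O)c2cccnc2n(-c2ccccc2)c1=O` lies nearest to it, and in this assay compound 1 gives 20.4%; the step of a number 2 percentage points lower from compound 1 to compound 2 (within the scatter) is within the scatter. Compound 3 `Cc1ccccc1NC(=O)c1c(O)c2cccnc2n(-c2ccccc2)c1=O` lies furthest, and in this assay compound 3 gives 9.8%; here the step of a number 8.6 percentage points lower from compound 2 to compound 3 (within the scatter) is also within the scatter, while a number 10.6 percentage points lower from compound 1 to compound 3 (beyond the scatter) is beyond it.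

Compound 4 `O=C(Nc1ccncc1)c1c(O)c2cccnc2n(-c2ccccc2)c1=O` has not yet been measured in this assay. It differs from compound 2 in one place: pyridin-4-yl in place of 2-(dimethylamino)ethyl on an amide-type nitrogen

The two steps that bear on this change both swap a chain on the amide-type nitrogen for a six-membered aromatic ring. From compound 2 the swap to 2-methylphenyl gave a number 8.6 percentage points lower from compound 2 to compound 3 (within the scatter), and from compound 1 the swap from butyl to 2-methylphenyl gave a number 10.6 percentage points lower from compound 1 to compound 3 (beyond the scatter). A step of that modest size and downward direction is therefore expected for compound 4, namely a number 7.4 percentage points lower from compound 2 to compound 4 (within the scatter). On that basis compound 4 is estimated to give 11% in this assay, with a likely range from 2% to 22%.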

Compound 4, a percentage reported as inhibition, in the whole organism at one dose (the size of the read-out at that dose, not a potency): 24.3%
Compound 4: middle estimate off by 13.3 percentage points, on the low side; the whole stated range lies below it.
By their numbers in this assay, from the lowest: compounds 3, 2, 1 and 4 (each within the scatter of the next, the first and the last beyond it).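

In this assay, a six-membered aromatic ring on the amide-type nitrogen does not by itself set a compound apart from one with a chain there: pyridin-4-yl in place of 2-(dimethylamino)ethyl gave a number 5.9 percentage points higher from compound 2 to compound 4 (within the scatter) and pyridin-4-yl in place of butyl gave a number 3.9 percentage points higher from compound 1 to compound 4 (within the scatter) in this series. Compound 3 had suggested that such a ring goes with a lower number, but that holds for 2-methylphenyl and not for pyridin-4-yl, as the change between these two rings gave a number 14.5 percentage points higher from compound 3 to compound 4 (beyond the scatter) on the same core. Nothing available here accounts for this gap between the two rings.

Compound 3 and compound 4 differ in both the ring nitrogen and the methyl group, so these compounds cannot show which of the two goes with the gap. A plain phenyl on the amide-type nitrogen would separate those two features, and pyridin-3-yl would show whether the place of the ring nitrogen matters to the number at this single oral dose.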